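Replacing methyl with iodo in compound 3

This account rests on a few compounds, and the source may have more. Where it says the series, first, only, none or still open, it means among the compounds named here.

Within the data shown here, in a physicochemical assay for lipophilicity, measured as octanol-water partition, at pH 7.4 (a lower number here means a more polar compound, a higher number a more lipophilic compound), compound 3 `Cc1cc(-c2nc3ccccc3s2)ccc1NS(=O)(=O)O` gives 0.6, the lowest of the two exact numbers so far. Compound 2 `O=S(=O)(O)Nc1ccc(-c2nc3ccccc3s2)cc1`, with hydrogen in place of the methyl, gives 3.4. Compound 1 `Nc1ccc(-c2nc3ccccc3s2)cc1I`, which has iodo but no sulfoamino group, reads > 3.3, and this is a limit of the assay rather than a number.

Compound 4 `O=S(=O)(O)Nc1ccc(-c2nc3ccccc3s2)cc1I` has not yet been measured. It carries iodo in place of methyl on an aromatic carbon, ortho to a sulfoamino group: iodo in place of methyl on an aromatic carbon.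

Among the measured compounds shown here, only one measured step bears on this change: a number 2.80 log units lower from compound 2 to compound 3 (beyond the scatter). That large step replaced hydrogen with methyl, so it does not directly give the size of a swap from methyl to iodo. Like compound 3 at 0.6, compound 4 has a group other than hydrogen on that carbon, so its number is expected to lie nearer to compound 3 than to compound 2. A moderate rise in this assay is still expected, with the estimated step being a number 0.60 log units higher from compound 3 to compound 4 (beyond the scatter). With so little data, the range stays wide. Compound 4 is expected at about 1.2, with an estimated range of 0.4 to 3.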

Compound 4, distribution coefficient: 1.8
Compound 4: middle estimate off by 0.60 log units, on the low side, within the range that was stated.
By their numbers in this assay, from the lowest: compound 3; then compound 4; then compound 2.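

In this assay, the group on the aromatic carbon ortho to a sulfoamino group turns out to matter beyond simply being something other than hydrogen: swapping methyl for iodo brings a number 1.20 log units higher from compound 3 to compound 4 (beyond the scatter). Iodo still does not restore the level of the hydrogen compound, with a number 1.60 log units lower from compound 2 to compound 4 (beyond the scatter), so both substituted compounds read lower than compound 2, although the earlier methyl step was larger, at a number 2.80 log units lower from compound 2 to compound 3 (beyond the scatter). Sulfo in place of hydrogen on the nitrogen brings a number at least 1.50 log units lower from compound 1 to compound 4 (beyond the scatter), but that size is only a bound, since compound 1 stands at a limit of the assay and not at a number: the limit of > 3.3 in this assay, at which 1 of the 4 values shown sits.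

Hydrogen, methyl and iodo are the only groups shown on this carbon, so they cannot establish a trend, and the compounds do not explain why either group lowers the reading. On these data alone, it remains open where chloro or methoxy on this carbon would fall relative to methyl and iodo, and whether the same order would hold with a carboxylic acid in place of the sulfoamino group.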